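From Trifluoromethoxy to Methylsulfanyl at an Assay Limit

The compounds below may be only part of what the source reports. "The series", "measured", "known", "first", "only" and "open" are said of these compounds alone.

Measured in an ADME assay on Raji cells (Homo sapiens) for cytotoxicity, with a stated time of 72 h; on this read-out lower numbers stand for an effect already at smaller amounts and higher numbers for an effect only at larger amounts of compound:
Compound 1 `Cc1cc(NC(=O)Nc2ccccc2OC(F)(F)F)c2ccccc2n1`: > 25000 nM (a limit)
Compound 2 `COc1ccc(NC(=O)Nc2cc(C)nc3ccccc23)cc1OC`: > 25000 nM (a limit)
Compound 3 `Cc1cc(NC(=O)Nc2cc(F)cc(F)c2)c2ccccc2n1`: > 25000 nM (a limit)

In this assay compound 1 gives > 25000 nM, which is a limit of the assay and not a number. It has no exact place in the series, and compound 2 and compound 3 stand the same way, with all three resting on (the limit of > 25000 nM in this assay, at which 3 of the 3 values shown sit).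

Compound 4 `CSc1ccccc1NC(=O)Nc1cc(C)nc2ccccc12` differs from compound 1 by carrying methylsulfanyl in place of trifluoromethoxy on an aromatic carbon, ortho to a large group (methylsulfanyl in place of trifluoromethoxy on an aromatic carbon). Going by the values given here, no two measured compounds differ in one place only, so no measured step shows how large such a change might be. Compound 1, compound 2 and compound 3 carry different groups on the shared core and all end at the limit of > 25000 nM in this assay, at which 3 of the 3 values shown sit, so no change beyond the usual scatter is expected. The expected step is a number no higher from compound 1 to compound 4 (the limit leaves the size open), and another limit is the likeliest report. For compound 4 the estimated value is 25000 nM. The expected range runs from 12000 nM to 50000 nM.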

Compound 4, half-maximal effective concentration: > 25000 nM
Compound 4 was reported as a limit; the forecaster's own chance of this, stated with the estimate: 85%; the middle value lies on the limit itself.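

Compound 1 and compound 4 both end at a limit and not at a number, so no step can be read for methylsulfanyl in place of trifluoromethoxy. The compounds shown leave open how the four would rank against one another, since all rest on one limit: the limit of > 25000 nM in this assay, at which 4 of the 4 values shown sit.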